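Swapping the aryl substituent in a kinase-binding series

The source may hold more compounds than are shown below. What is called first, only, known or untested is meant among the compounds shown, and "the series" means these compounds.

Measured compounds:
compound 1, `CCCS(=O)(=O)Nc1ccc(F)c(C(=O)c2n[nH]c3ncc(-c4ccccc4F)cc23)c1F`, gives 2% in an assay for binding affinity to dual specificity mitogen-activated protein kinase kinase 4 (Homo sapiens), read by KINOMEscan, tested at 100 nM; a lower number here means a stronger effect, a higher number a weaker effect of the compound at the concentration tested;
compound 2, `CCCS(=O)(=O)Nc1ccc(F)c(C(=O)c2n[nH]c3ncc(-c4ccc(C(C)C)cc4)cc23)c1F`, gives 17%;
compound 3, `CCCS(=O)(=O)Nc1ccc(F)c(C(=O)c2n[nH]c3ncc(-c4cccc(C(F)(F)F)c4)cc23)c1F`, gives 57%.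

Compound 2 stands second highest of the three numbers: compound 1 lies a number 15 percentage points higher from compound 1 to compound 2 (beyond the scatter), and compound 3 lies a number 40 percentage points higher from compound 2 to compound 3 (beyond the scatter). Compound 4, `CCCS(=O)(=O)Nc1ccc(F)c(C(=O)c2n[nH]c3ncc(-c4ccc(S(=O)(=O)NC(C)=O)cc4)cc23)c1F`, differs from compound 2 by acetylsulfamoyl in place of isopropyl on an aromatic carbon. Among the compounds with values here, no measured step exchanges a group of this kind, so only the three steps at the same aromatic carbon bear on it, and they show that changing this group moves the read-out modestly to largely, as in a number 55 percentage points higher from compound 1 to compound 3 (beyond the scatter). A step upward from compound 2 is expected, though its size is uncertain; the estimate for compound 4 is 35%, ranging from 5% to 80%, which corresponds to an expected a number 18 percentage points higher from compound 2 to compound 4 (beyond the scatter).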

Compound 4, a percentage reported as activity, at one concentration (the size of the read-out at that concentration, not a potency): 0.35%
The estimate for compound 4 lay 34.7 percentage points above the measured number; measured number outside the range, below it.
By their numbers in this assay, from the lowest: compounds 4 and 1 (each within the scatter of the next); then compound 2; then compound 3.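

In this assay, acetylsulfamoyl in place of isopropyl gives a number 16.7 percentage points lower from compound 2 to compound 4 (beyond the scatter), so this ring position accepts a larger group, one with a hydrogen-bond donor and acceptors, without losing binding. Until now, compound 1 stood alone at the low end, but compound 4, at 0.35%, lies within the scatter of compound 1, at 2%. Nothing measured here explains this gain. From the compounds shown here alone, it remains open whether the whole acetylsulfamoyl group is needed, or whether a plain sulfamoyl group, a carboxylic acid or an amine at this place would match it.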